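Pyridinyloxy for chloro on two related acylguanidine cores

This account rests on a few compounds, and the source may have more. Where it says the series, first, only, none or still open, it means among the compounds named here.

Compound 1 `Cc1c(C(=O)N=C(N)N)cc(S(C)(=O)=O)c(Cl)c1C` is measured in a functional assay for inhibition of sodium/hydrogen exchanger (Oryctolagus cuniculus) (a higher number here means a weaker inhibitor, a lower number a stronger inhibitor), at 58 nM. Compound 3 `Cc1c(C(=O)N=C(N)N)cc(S(C)(=O)=O)c(Oc2cccnc2)c1C` carries (pyridin-3-yl)oxy in place of chloro on an aromatic carbon and in this assay compound 3 gives 23 nM, which makes the step of a 2.5-fold lower number from compound 1 to compound 3 (0.40 log units; beyond the scatter). Compound 2 `Cc1c(C(=O)N=C(N)N)ccc(Cl)c1S(C)(=O)=O` is built on a different core; the difference between the two cores is not broken down here. In this assay compound 2 gives 1300 nM, the highest of the three numbers, with compound 1 and compound 3 both well beyond the scatter below it.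

Compound 4 `Cc1c(C(=O)N=C(N)N)ccc(Oc2cccnc2)c1S(C)(=O)=O` is not yet measured. It relates to compound 2 by (pyridin-3-yl)oxy in place of chloro on an aromatic carbon. Among the measured compounds shown here, this is the same kind of change as the one from compound 1 to compound 3, but not the same: around the place in compound 1 the chloro is ortho to a methyl group and ortho to a methylsulfonyl group, while in compound 2 it is ortho to a methylsulfonyl group and meta to a methyl group. For the measured compounds named here, only one measured instance of the change exists, so how far it carries over to the second core is uncertain.

Going by the values given here, the step from compound 2 to compound 4 in this assay is expected to be about a 2.5-fold lower number from compound 2 to compound 4 (0.40 log units; beyond the scatter), resting on the single step of a 2.5-fold lower number from compound 1 to compound 3 (0.40 log units; beyond the scatter) seen on the first core. Compound 4 is therefore estimated at 520 nM, with a range from 200 nM to 1400 nM.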

Compound 4, half-maximal inhibitory concentration: 2200 nM
The estimate for compound 4 lay 4.2-fold (0.63 log units) below the measured number, and the stated range ends below it.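

In this assay, the exchange of chloro for (pyridin-3-yl)oxy reads as a 1.7-fold higher number from compound 2 to compound 4 (0.23 log units; within the scatter), so the gain seen on the core of compound 1 does not reappear on the core of compound 2, and the two outcomes differ: the same change on two cores in this assay, a 2.5-fold lower number (0.40 log units; beyond the scatter) from compound 1 to compound 3 and a 1.7-fold higher number (0.23 log units; within the scatter) from compound 2 to compound 4, 4.3-fold (0.63 log units) apart, beyond the scatter of two such steps

For this pair of cores, the step measured on one therefore gave no reliable guide to the step on the other, and a value for this change should not be carried across the series without a measurement on the core concerned. Among the compounds shown here, these results do not show which structural difference between the cores is responsible, nor do they set a general rule, as each core contributes only one instance of the change and no other core is available for comparison.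

Still open, as far as these compounds go, is whether other replacements for chloro, such as a phenoxy group, a (pyridin-4-yl)oxy group or an amine, would also diverge between the two cores or would behave alike on both. Also open, from the compounds shown here alone, is how much of the divergence follows the methyl group that compound 1 carries and compound 2 lacks, and how much follows the different placement of the methylsulfonyl group.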